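Urea-bearing chain variant of compound 1

The source may hold more compounds than are shown below. What is called first, only, known or untested is meant among the compounds shown, and "the series" means these compounds.

Compound 1 `C/C(=C/CN(C[C@H]1Cc2ccccc2CN1)[C@H]1CCCc2cccnc21)CN` is the reference point of the series. Within the data shown here, in a functional assay on CCRF-CEM cells for antagonist activity at C-X-C chemokine receptor type 4 (Homo sapiens), read by calcium flux, with stated times of 25 min and 90 s (a higher number here means a weaker inhibitor, a lower number a stronger inhibitor), compound 1 gives 8.6 nM, the lowest of the two numbers so far. Its nearest neighbour is compound 2 `C/C(CN(C[C@H]1Cc2ccccc2CN1)[C@H]1CCCc2cccnc21)=C(/F)CN`, which in this assay gives 1800 nM, with a 210-fold higher number from compound 1 to compound 2 (2.32 log units; beyond the scatter). That single measured step shows that a change to the side chain on the saturated chain carbon bound to an amine nitrogen has produced a large shift toward a weaker inhibitor.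

Compound 3 `NC(=O)NC/C=C\CN(C[C@H]1Cc2ccccc2CN1)[C@H]1CCCc2cccnc21` has not been measured. It differs from compound 1 as follows: a group of 7 heavy atoms (4 carbon, 2 nitrogen, 1 oxygen; no ring) in place of a group of 5 heavy atoms (4 carbon, 1 nitrogen; no ring), on a saturated chain carbon bound to an amine nitrogen. The step from compound 1 to compound 2 is the only one that bears on this change; it also alters that side chain, and it was large. Among the measured compounds shown here, the change to compound 3 is at least as extensive, so a step of considerable size toward a higher number in this assay is expected, though with wide uncertainty given only one comparison. For compound 3 a step of a 35-fold higher number from compound 1 to compound 3 (1.54 log units; beyond the scatter) is expected. Compound 3 is therefore estimated at 300 nM in this assay, within a range of 40 nM to 2500 nM.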

Compound 3, half-maximal inhibitory concentration: 210 nM
Compound 3: middle estimate off by 1.4-fold (0.15 log units), on the high side; low and high end bracket the measured number.
By their numbers in this assay, from the lowest: compound 1; then compound 3; then compound 2.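

In this assay, a second replacement on a saturated chain carbon bound to an amine nitrogen also moves away from compound 1 (a 24-fold higher number from compound 1 to compound 3 (1.39 log units; beyond the scatter)), so both replacement chains shown here give a weaker inhibitor than compound 1. The two replacements are not equivalent, however: the urea-bearing chain keeps clearly more of the activity than the fluorine-bearing chain (an 8.6-fold lower number from compound 2 to compound 3 (0.93 log units; beyond the scatter)), which shows that the outcome at this position depends on the chain present and does not fall to one common low level whenever the chain of compound 1 is replaced. No supporting measurement accounts for either step or for the gap between compounds 2 and 3.

The compounds shown leave open which part of the chain change in compound 3 carries the loss, since the group is replaced as a whole and the contribution of its carbonyl-bearing end cannot be separated from that of the rest of the chain. Also open, as far as these compounds go, is how this position would respond to a chain ending in a simple amide or a carboxylic acid, or to a longer chain ending in an amine.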